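A few compounds are considered here, and "the series" means these few. Any claim that something is new, unique, unknown or untested is made for them only; others in the source may bear on it.

Of the compounds shown here, three have been measured in a physicochemical assay for lipophilicity, read by HPLC, at pH 7.4; a higher number here means a more lipophilic compound, a lower number a more polar compound. Compound 1 `O=C(O)Cc1ccc(-c2cccc(NC(=O)OCc3ccccc3)c2)cc1` gives 3.19. Compound 2 `O=C(O)Cc1ccc(-c2ccc(CN3CC(=O)N(c4ccccc4)C3=O)cc2)cc1` gives 2.18. Compound 3 `O=C1CN(Cc2ccc(-c3ccccc3)cc2)C(=O)N1c1ccccc1` gives 6.24, the highest of the three. Compound 1 and compound 2 have different cores, and the difference between the two cores is not broken down here.

Compound 2 and compound 3 differ in one place: hydrogen in place of carboxymethyl on an aromatic carbon. This change carries the step of a number 4.06 log units higher from compound 2 to compound 3 (beyond the scatter). Among the measured compounds shown here, the group that leaves carries an acid, and its loss is the only change between the two.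

Compound 4 `O=C(Nc1cccc(-c2ccccc2)c1)OCc1ccccc1` has not yet been measured in this assay. It differs from compound 1 in exactly the same way: hydrogen in place of carboxymethyl on an aromatic carbon. Both changes sit in the same kind of place, on a six-membered ring of carbon only, para to a large group, so the change is the same and only the core around it differs.

For the measured compounds named here, because a number 4.06 log units higher from compound 2 to compound 3 (beyond the scatter) was so large, a large rise is also expected for compound 4, though with a wide band, since only one earlier example exists and its core is not the core of compound 1. The estimated step is a number 2.81 log units higher from compound 1 to compound 4 (beyond the scatter). For compound 4 the value in this assay is expected to be 6, most likely between 4.8 and 7.2.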

Compound 4, distribution coefficient: 7.52
For compound 4 the middle estimate is 1.52 log units below the measured one; measured number above the stated range.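

In this assay, hydrogen in place of carboxymethyl on an aromatic carbon gives a number 4.33 log units higher from compound 1 to compound 4 (beyond the scatter), and this step, like a number 4.06 log units higher from compound 2 to compound 3 (beyond the scatter), is large, beyond the scatter and in the same direction, so the change carried over from one core to the other with its direction intact and its size still large. Among the compounds shown here, this rests on only two pairs, each with the change in the same kind of place, para to a large group, so it does not show that the step would hold on any other core, or that one fixed size can be added to a new compound. The data shown also offer nothing that explains why the number rises with this change.

The compounds shown leave open whether other groups in the same place would behave the same way, since each pair compares only carboxymethyl with hydrogen, and an amine or a longer chain ending in a carboxylic acid is not among them. They also leave open whether the change gives a similar step when it sits elsewhere on the ring, or on a third core.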